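Diethylamino sulfonamide as a variant on compound 1

A few compounds are considered here, and "the series" means these few. Any claim that something is new, unique, unknown or untested is made for them only; others in the source may bear on it.

Measured so far:
compound 1, `O=C(NCc1ccncc1)Nc1ccc(S(=O)(=O)Nc2ccccc2)cc1`, 410 nM
compound 2, `O=C(NCc1cn[nH]c1)Nc1ccc(S(=O)(=O)c2ccccc2)cc1`, 28 nM
compound 3, `CCOC(=O)c1ccc(NC(=O)NCc2cnco2)cc1`, 6900 nM

In an assay on isolated protein for activation of Nicotinamide phosphoribosyltransferase (Homo sapiens) (a lower number here means that less compound is needed, a higher number that more compound is needed for the effect), compound 1 gives 410 nM, the second highest of the three numbers. Its nearest neighbour is compound 2, whose value of 28 nM lies beyond the scatter on the lower side; furthest away is compound 3, whose value of 6900 nM lies beyond the scatter on the higher side. Within the data shown here, these three compounds differ in several places at once, so no single step between them can be read off.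

Compound 4, `CCN(CC)S(=O)(=O)c1ccc(NC(=O)NCc2ccncc2)cc1`, is not yet measured. It differs from compound 1 in one place: diethylamino in place of anilino on a sulfonyl sulfur. Among the measured compounds shown here, no measured pair shows this change, so the size of the step has to be guessed. In this assay a moderate upward step in a 2.2-fold higher number from compound 1 to compound 4 (0.34 log units; beyond the scatter) is expected, since the aromatic ring that leaves is absent in compound 4. Compound 4 is therefore estimated at 900 nM, within a range of 250 nM to 3500 nM.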

Compound 4, half-maximal effective concentration: 384 nM
Estimate against measurement, compound 4: 2.3-fold (0.37 log units) above; the range from low to high includes it.
By their numbers in this assay, from the lowest: compound 2; then compounds 4 and 1 (each within the scatter of the next); then compound 3.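

In this assay, diethylamino in place of anilino on a sulfonyl sulfur gives a 1.1-fold lower number from compound 1 to compound 4 (0.03 log units; within the scatter), the only single-place comparison shown in this series. For this pair, the six-membered aromatic ring of carbon and the hydrogen-bond donor that leave with anilino can therefore be lost without a difference beyond the scatter, and a non-ring group with no hydrogen-bond donor serves equally well at this place. No measurement shown here explains why the two groups read alike.

Going by these compounds, it remains open whether a shorter amine such as dimethylamino or a cyclic amine such as morpholine or piperidine would read the same on the sulfonyl sulfur. It is also unknown whether this equivalence would hold if the rest of the core of compound 1 were changed.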